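Methoxy for chloro on the pyrimidinone aryl arm

This account rests on a few compounds, and the source may have more. Where it says the series, first, only, none or still open, it means among the compounds named here.

Among the compounds with values here, compound 2 `COc1ccc(C2CC(c3ccc(Cl)cc3)=NN2c2nc(-c3ccc(Cl)cc3)c(C#N)c(=O)n2C)cc1` holds the lower of the two numbers so far: in a functional assay on MCF7 cells (Homo sapiens) for antiproliferative activity, with a stated time of 72 h (a higher number here means a weaker inhibitor, a lower number a stronger inhibitor), compound 2 gives 27300 nM, whereas compound 1 `COc1ccc(C2=NN(c3nc(-c4ccccc4)c(C#N)c(=O)n3C)C(c3ccc(OC)cc3)C2)cc1` gives 127000 nM, a gap beyond the scatter. Compound 3 `COc1ccc(C2=NN(c3nc(-c4ccc(Cl)cc4)c(C#N)c(=O)n3C)C(c3ccc(OC)cc3)C2)cc1` is not yet measured; it differs from compound 2 by methoxy in place of chloro on an aromatic carbon. Within the data shown here, no measured pair isolates this change, so the direction is uncertain; a modest rise toward the number of compound 1 is expected, roughly a 2.2-fold higher number from compound 2 to compound 3 (0.34 log units; beyond the scatter). Compound 3 is therefore estimated at 60000 nM, within 20000 nM to 150000 nM.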

Compound 3, half-maximal inhibitory concentration: 99800 nM
Beside the measured number, compound 3's estimate is 1.7-fold (0.22 log units) below it; the measured number falls inside the stated range.
By their numbers in this assay, from the lowest: compound 2; then compounds 3 and 1 (each within the scatter of the next).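

Within this assay the pair isolates the change at this position: 4-chlorophenyl to 4-methoxyphenyl gives a 3.7-fold higher number from compound 2 to compound 3 (0.56 log units; beyond the scatter) and so costs activity. The separate change, chloro in place of hydrogen on an aromatic carbon, gives a 1.3-fold lower number from compound 1 to compound 3 (0.10 log units; within the scatter) and does not register while methoxy is present on the other arm. No measurement on hand accounts for either step.

From the compounds shown here alone, whether an amine or a longer alkoxy chain at this position would match compound 2 remains open. Also open, going by these compounds, is whether the chloro effect holds in other compounds.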